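A few compounds are considered here, and "the series" means these few. Any claim that something is new, unique, unknown or untested is made for them only; others in the source may bear on it.

Compound 1 `COc1ccc(/C=C\c2cc(OC)c(OC)c(OC)c2)cc1OCc1ccc(CN2CCCC[C@@H]2C(=O)O)cc1`: > 50000 nM (a limit)
Compound 2 `COc1ccc(/C=C\c2cc(OC)c(OC)c(OC)c2)cc1OCc1ccc(CO)cc1`: > 50000 nM (a limit)
Compound 3 `COc1ccc(/C=C\c2cc(OC)c(OC)c(OC)c2)cc1OCc1ccc(CN2CC(C(=O)O)C2)cc1`: > 50000 nM (a limit)

In an ADME assay on NCM460 cells (Homo sapiens) for cytotoxicity, read by CCK-8 assay, with a stated time of 48 h (a lower number here means a stronger inhibitor, a higher number a weaker inhibitor), compound 3 gives > 50000 nM. This is a limit and not a number. Among the measured compounds shown here, it is also the position of the whole series so far: the limit of > 50000 nM in this assay, at which 3 of the 3 values shown sit.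

The step now in question leads to compound 4 `COc1ccc(/C=C\c2cc(OC)c(OC)c(OC)c2)cc1OCc1ccc(CN2CCCCC2C(=O)NCCN)cc1`. It is 2-((2-aminoethyl)carbamoyl)piperidin-1-yl in place of 3-carboxyazetidin-1-yl on a saturated chain carbon bound to an aromatic carbon. For the measured compounds named here, three measured steps bear on this place on the molecule: a step that the two limits leave unreadable from compound 1 to compound 2, a step that the two limits leave unreadable from compound 1 to compound 3 and a step that the two limits leave unreadable from compound 2 to compound 3. Both ends of each are limits, so none of them gives a size that could be carried over to the new group. The hydroxy, 2-carboxypiperidin-1-yl and 3-carboxyazetidin-1-yl compounds all end at the same limit, but 2-((2-aminoethyl)carbamoyl)piperidin-1-yl has not yet been tested in this assay. The expectation is therefore cautious: compound 4 will probably stay at or near the limit, with a modest move towards a stronger reading as the only direction the assay could resolve. The expected step is an at least 1.2-fold lower number from compound 3 to compound 4 (0.09 log units; that floor lies within the scatter). For compound 4 the estimated value is 40000 nM, with an expected range from 12000 nM to 70000 nM.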

Compound 4, half-maximal inhibitory concentration: > 50000 nM
Compound 4: no number, only a limit (the forecaster's own chance of this, stated with the estimate: 60%); middle value at least 1.2-fold (0.09 log units) from the limit.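

In this assay compound 4 gives > 50000 nM, which is a limit and not a number. With compound 1, compound 2 and compound 3 also at limits, none of the steps to compound 4 can be read. The compounds shown leave open whether any group at this place would give a measurable number in this assay: the limit of > 50000 nM in this assay, at which 4 of the 4 values shown sit.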